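This account rests on a few compounds, and the source may have more. Where it says the series, first, only, none or still open, it means among the compounds named here.

Measured so far:
Compound 1 `CC1(C)OB(c2ccc(O)c(NC(=O)COc3ccc(C4CCCCC4)cc3)c2)OC1(C)C`: 13400 nM
Compound 2 `CCc1ccc(OCC(=O)Nc2cc(B(O)O)ccc2O)cc1`: 14900 nM
Compound 3 `O=C(COc1ccc(-c2ccccc2)cc1)Nc1cc(B(O)O)ccc1O`: 85900 nM

In a functional assay on HeLa cells (Homo sapiens) for inhibition, read by MTT assay, with a stated time of 48 h (on this read-out higher numbers stand for weaker inhibition of growth and lower numbers for stronger inhibition of growth), compound 3 gives the highest of the three numbers. The step of a 5.8-fold higher number from compound 2 to compound 3 (0.76 log units; beyond the scatter) separates it from its nearest neighbour, and compound 1 lies further away still, with a number lower than that of compound 3 by a gap beyond the scatter.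

Compound 4 `O=C(COc1ccc(C2CCCCC2)cc1)Nc1cc(B(O)O)ccc1O` differs from compound 3 by cyclohexyl in place of phenyl on an aromatic carbon. Within the data shown here, only one measured step touches this position, a 5.8-fold higher number from compound 2 to compound 3 (0.76 log units; beyond the scatter), in which an alkyl group gave way to phenyl and the number rose. The change to compound 4 moves back from phenyl to a non-aromatic ring, so a drop is the natural expectation. Compound 1 carries the same cyclohexyl group with its boron in a different form and gives 13400 nM, which points the same way. For compound 4 the expected step is a 4.8-fold lower number from compound 3 to compound 4 (0.68 log units; beyond the scatter), a modest fall. The estimate for compound 4 is 18000 nM, with a likely range from 7000 nM to 50000 nM.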

Compound 4, concentration for 50% growth inhibition: 29200 nM
For compound 4 the middle estimate is 1.6-fold (0.21 log units) below the measured one; the measured number falls inside the stated range.
By their numbers in this assay, from the lowest: compounds 1, 2 and 4 (each within the scatter of the next, the first and the last beyond it); then compound 3.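

In this assay, cyclohexyl in place of phenyl gives a 2.9-fold lower number from compound 3 to compound 4 (0.47 log units; beyond the scatter) on a ring of the same size that is non-aromatic, so the change of ring type alone moves the number. Cyclohexyl in place of ethyl gives a 2.0-fold higher number from compound 2 to compound 4 (0.29 log units; within the scatter) and so cannot be told apart from ethyl here, leaving phenyl as the only one of these three groups that stands apart. The boron group also matters slightly, since replacing the larger group with its five-membered ring by the smaller one without a ring gives a 2.2-fold higher number from compound 1 to compound 4 (0.34 log units; beyond the scatter) when cyclohexyl stays in place.

Nothing available explains these shifts. As far as these compounds go, whether a methoxy group, an amine or a longer chain at this place would behave like phenyl or like cyclohexyl remains open.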